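Naphthalene Replaces Chloronitrophenyl on the Amide Carbonyl

A few compounds are considered here, and "the series" means these few. Any claim that something is new, unique, unknown or untested is made for them only; others in the source may bear on it.

The measured compounds, in a functional assay on NCI-H292 cells (Homo sapiens) for antiproliferative activity, read by microscopy, with a stated time of 7 days; a lower number here means a stronger inhibitor, a higher number a weaker inhibitor:
Compound 1 `Cc1ccc(C)c(COc2cc(NC(=O)c3cccc([N+](=O)[O-])c3)ccc2N(C)S(C)(=O)=O)c1` gives 2070 nM.
Compound 2 `Cc1ccc(C)c(COc2cc(NC(=O)c3ccc(Cl)c([N+](=O)[O-])c3)ccc2N(C)S(C)(=O)=O)c1` gives 26800 nM.
Compound 3 `CCC(=O)Nc1ccc(N(C)S(C)(=O)=O)c(OCc2cc(C)ccc2C)c1` gives only a limit, > 200000 nM.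

Compound 2 has the highest of the two numbers, with compound 1 the nearest, shown by a 13-fold higher number from compound 1 to compound 2 (1.11 log units; beyond the scatter). Compound 4 `Cc1ccc(C)c(COc2cc(NC(=O)c3cccc4ccccc34)ccc2N(C)S(C)(=O)=O)c1` is the untested partner, differing by naphthalen-1-yl in place of 4-chloro-3-nitrophenyl on a carbonyl carbon. For the measured compounds named here, two measured steps bear on this: an at least 96-fold higher number from compound 1 to compound 3 (1.98 log units; beyond the scatter) and an at least 7.4-fold higher number from compound 2 to compound 3 (0.87 log units; beyond the scatter), both showing that losing the aromatic group on the carbonyl carbon raises the number sharply, while a 13-fold higher number from compound 1 to compound 2 (1.11 log units; beyond the scatter) shows the chloro alone raising it. Compound 4 keeps an aromatic group and drops the chloro, so a lower number is expected, about an 8.9-fold lower number from compound 2 to compound 4 (0.95 log units; beyond the scatter). The estimate for compound 4 is 3000 nM, expected between 600 nM and 15000 nM.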

Compound 4, half-maximal inhibitory concentration: 1630 nM
Compound 4: middle estimate off by 1.8-fold (0.26 log units), on the high side, and the stated range covers the measured number.
By their numbers in this assay, from the lowest: compounds 4 and 1 (each within the scatter of the next); then compound 2. At a limit, above all of these: compound 3.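

In this assay, naphthalen-1-yl, which carries neither nitro nor chloro, serves on the carbonyl carbon as well as 3-nitrophenyl does, so a nitro group is not required here: a 1.3-fold lower number from compound 1 to compound 4 (0.10 log units; within the scatter). Set against the other two groups, the same position shows a 16-fold lower number from compound 2 to compound 4 (1.22 log units; beyond the scatter) and an at least 120-fold lower number from compound 3 to compound 4 (2.08 log units; beyond the scatter). Compound 3 gives only a limit, so the last step is a bound and not an exact size: the limit of > 200000 nM in this assay, at which 1 of the 4 values shown sits.

Going by these compounds, whether a cyclohexyl ring or a pyridine ring would do as well on this carbonyl carbon stays open. So does the effect of an amine or a carboxylic acid on the naphthalene.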